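The source may hold more compounds than are shown below. What is called first, only, known or untested is meant among the compounds shown, and "the series" means these compounds.

Cytotoxicity in an ADME assay on MT4 cells (Homo sapiens) for activation, read by MTT assay (a higher number here means that more compound is tolerated, a lower number that less compound is tolerated), is summarized for a small set built on two closely related cores. Compound 1 `Cc1c(Cc2c(F)cccc2Cl)nc(SC(C)C)[nH]c1=O` gives > 76000 nM in this assay, which is a limit of the assay and not a number. Compound 2 `CCC(C)Sc1nc(Cc2c(F)cccc2Cl)c(C)c(=O)[nH]1` gives > 73000 nM in this assay, again a limit. The change from compound 1 to compound 2 is methyl in place of hydrogen on a saturated chain carbon, two bonds along the chain from a sulfur; the step that the two limits leave unreadable from compound 1 to compound 2 cannot be sized because the limit of > 76000 nM in this assay, at which 1 of the 3 values shown sits, and the limit of > 73000 nM in this assay, at which 1 of the 3 values shown sits, both sit at limits. Compound 3 `CCCSc1nc(C(C)c2c(F)cccc2Cl)cc(=O)[nH]1` carries a different core from compound 1; the difference between the two cores is not broken down here. Compound 3 gives > 75000 nM in this assay, a limit. Compound 4 `CCC(C)Sc1nc(C(C)c2c(F)cccc2Cl)cc(=O)[nH]1` differs from compound 3 by methyl in place of hydrogen on a saturated chain carbon bound to a saturated chain carbon and a sulfur. This is the same kind of change as from compound 1 to compound 2, but here the place is on a saturated chain carbon bound to a saturated chain carbon and a sulfur, rather than two bonds along the chain from a sulfur. The expected step is a number no higher from compound 3 to compound 4 (the limit leaves the size open). This rests on compound 3 sitting at the limit of > 75000 nM in this assay, at which 1 of the 3 values shown sits, and on compound 2 sitting at the limit (the limit of > 73000 nM in this assay, at which 1 of the 3 values shown sits). Compound 4 is expected at 75000 nM, between 40000 nM and 160000 nM, most likely reported once more only as a limit.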

Compound 4, half-maximal cytotoxic concentration: > 73000 nM
Compound 4 ended at the assay's limit; the forecaster's own chance of this, stated with the estimate: 85%; the middle value is on the limit's open side.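

In this assay compound 4 gives > 73000 nM, a limit of the assay and not a number. Compound 3 also sits at a limit, so no step can be read between compound 3 and compound 4. The compounds shown leave open where the actual half-maximal cytotoxic concentration of any of them lies.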